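A few compounds are considered here, and "the series" means these few. Any claim that something is new, unique, unknown or untested is made for them only; others in the source may bear on it.

Three measured compounds share one core and differ mainly in the group attached to the carbonyl carbon of the amide. Compound 1 `CCN1CCN(c2cc(C)c3cc(NC(=O)c4cccc(Cl)c4)ccc3n2)CC1` carries a 3-chlorophenyl there and gives 17800 nM in a functional assay on SK-BR-3 cells (Homo sapiens) for antiproliferative activity, read by MTT assay, with a stated time of 72 h; on this read-out higher numbers stand for weaker inhibition and lower numbers for stronger inhibition. Compound 2 `Cc1cc(NCCN(C)C)nc2ccc(NC(=O)c3ccc(Cl)c(Cl)c3)cc12` bears a 3,4-dichlorophenyl, with a different amine side chain on the core, and gives 6670 nM in this assay. Compound 3 `CCN1CCN(c2cc(C)c3cc(NC(=O)c4ccc5ccccc5n4)ccc3n2)CC1` carries a quinolin-2-yl and gives 3760 nM in this assay, the lowest of the three numbers; its gap to compound 1 is beyond the scatter, its gap to compound 2 is not. Among the compounds with values here, the one step measured along this line, quinolin-2-yl in place of 3-chlorophenyl on a carbonyl carbon, gave a 4.7-fold lower number from compound 1 to compound 3 (0.68 log units; beyond the scatter).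

Compound 4 `CCN1CCN(c2cc(C)c3cc(NC(=O)c4ccc(F)c(F)c4)ccc3n2)CC1` is the next compound, and it differs from compound 3 in one place: 3,4-difluorophenyl in place of quinolin-2-yl on a carbonyl carbon. This reverses the direction of the step measured from compound 1 to compound 3, returning to a halogenated phenyl ring, now with two fluorines rather than one chlorine. Within the data shown here, no measured step reports a difluorophenyl directly, so the step from compound 1 to compound 3 is the only guide. Compound 4 is therefore expected to give a higher number than compound 3, roughly a 2.7-fold higher number from compound 3 to compound 4 (0.42 log units; beyond the scatter), landing between the values of compound 1 and compound 2. The estimate for compound 4 in this assay is 10000 nM, with a range from 3500 nM to 30000 nM.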

Compound 4, half-maximal inhibitory concentration: 1980 nM
The estimate for compound 4 lay 5.1-fold (0.70 log units) above the measured number, and the stated range ends above it.
By their numbers in this assay, from the lowest: compounds 4, 3 and 2 (each within the scatter of the next, the first and the last beyond it); then compound 1.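

The 3,4-difluorophenyl and quinolin-2-yl groups cannot be told apart on the carbonyl carbon in this assay, with a 1.9-fold lower number from compound 3 to compound 4 (0.28 log units; within the scatter). The step from compound 1 to compound 3 therefore does not show that quinolin-2-yl is needed here, since a single aromatic ring of carbon only, without the hydrogen-bond acceptor, serves as well. Halogenated phenyl groups are not interchangeable either, as the change from 3-chlorophenyl to 3,4-difluorophenyl gives a 9.0-fold lower number from compound 1 to compound 4 (0.95 log units; beyond the scatter).

The compounds shown cannot separate the effect of having two halogens from that of fluorine replacing chlorine, and a 3-fluorophenyl or 3-aminophenyl group on the same core would be needed to address this. Nothing shown here explains why these steps take the sizes they do.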